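The source may hold more compounds than are shown below. What is called first, only, known or untested is meant among the compounds shown, and "the series" means these compounds.

Measured compounds:
Compound 1 `C=CCOc1cc(/C=C/C(=O)c2ccc(OC)c3c2OC(C)(C)C=C3)ccc1OC` gives in a functional assay on A-375 cells (Homo sapiens) for cytotoxicity, read by MTT assay (on this read-out lower numbers stand for stronger inhibition and higher numbers for weaker inhibition), only a limit, > 10000 nM.
Compound 2 `COc1ccc(/C=C/C(=O)c2ccc(OC)c3c2OC(C)(C)C=C3)cc1OC(=O)C(C)C` gives in this assay a number, 310 nM.

Within the data shown here, compound 2 thus holds the only real number here, the other value being a limit. Compound 3 `COc1ccc(/C=C/C(=O)c2ccc(OC)c3c2OC(C)(C)C=C3)cc1OS(=O)(=O)Cc1ccccc1` differs from compound 2 by benzylsulfonyl in place of isopropylcarbonyl on an oxygen on an aromatic ring. Among the measured compounds shown here, the only measured step, an at least 32-fold lower number from compound 1 to compound 2 (1.50 log units; beyond the scatter), also exchanged the group on an oxygen on an aromatic ring, but it says nothing about a benzylsulfonyl there, so the direction of the new step is open. The step of a 1.9-fold higher number from compound 2 to compound 3 (0.29 log units; within the scatter) is expected to be modest, with wide uncertainty. Compound 3 is therefore estimated at 600 nM, between 150 nM and 3000 nM.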

Compound 3, half-maximal inhibitory concentration: > 10000 nM
Compound 3 gave a limit, no number; the forecaster's own chance of this, stated with the estimate: 15%; at least 16-fold (1.22 log units) between middle value and limit.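

Exchanging isopropylcarbonyl for benzylsulfonyl on an oxygen on an aromatic ring gives an at least 32-fold higher number from compound 2 to compound 3 (1.50 log units; beyond the scatter) in this assay. The earlier step showed that allyl at this oxygen falls far short of isopropylcarbonyl, and benzylsulfonyl now does too, so among the three groups shown only isopropylcarbonyl gives a readable number. Compound 1 and compound 3 both end at a limit rather than a number, so the step between them cannot be read: the limit of > 10000 nM in this assay, at which 2 of the 3 values shown sit.

Open, from the compounds shown here alone, is whether other carbonyl groups on this oxygen, such as acetyl or a longer chain like hexanoyl, keep the effect of isopropylcarbonyl. Also open, going by these compounds, is how a free hydroxyl group there would compare.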